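Sulfonamide ring size and cytotoxicity across two cores

The source may report more compounds than this note shows. Statements on the series, on what has been measured and on what is new or still open speak of the compounds shown alone.

Compound 3 `CN1CCCN(S(=O)(=O)c2ccc(-c3ccc4nncc(Nc5ccc(OCc6cccc(F)c6)c(Cl)c5)c4c3)cc2)CC1` and compound 1 `CN1CCN(S(=O)(=O)c2ccc(-c3ccc4nncc(Nc5ccc(OCc6cccc(F)c6)c(Cl)c5)c4c3)cc2)CC1` share one core; compound 2 `CN1CCCN(S(=O)(=O)c2ccc(C3=CC4N=CN=C(Nc5ccc(OCc6cccc(F)c6)c(Cl)c5)C4S3)cc2)CC1` and the unmeasured compound 4 `CN1CCN(S(=O)(=O)c2ccc(C3=CC4N=CN=C(Nc5ccc(OCc6cccc(F)c6)c(Cl)c5)C4S3)cc2)CC1` share another, and the difference between the two cores is not broken down here. In a toxicity assay on HepG2 cells (Homo sapiens) for cytotoxicity, read by MTT assay, with a stated time of 48 h (on this read-out higher numbers stand for lower toxicity in this test and lower numbers for higher toxicity in this test), compound 3 gives 7.3 uM. Compound 1 reaches only a limit of this assay, > 15 uM. The change 4-methylpiperazin-1-yl in place of 4-methyl-1,4-diazepan-1-yl on a sulfonyl sulfur thus gave an at least 2.0-fold higher number from compound 3 to compound 1 (0.31 log units; beyond the scatter), a step whose size is bounded because of the limit of > 15 uM in this assay, at which 2 of the 3 values shown sit. Compound 2 likewise gives only a limit in this assay, > 15 uM. The same change, (4-methylpiperazin-1-yl in place of 4-methyl-1,4-diazepan-1-yl on a sulfonyl sulfur), leads from compound 2 to compound 4. Compound 4 is expected to sit at 25 uM, since the same change produced an at least 2.0-fold higher number from compound 3 to compound 1 (0.31 log units; beyond the scatter). The step expected is a step that the limit leaves unreadable from compound 2 to compound 4. For compound 4 the expected range runs from 12 uM to 50 uM.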

Compound 4, half-maximal toxic concentration: > 15 uM
Compound 4 ended at the assay's limit; the forecaster's own chance of this, stated with the estimate: 80%; the middle value lies beyond the limit too.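

No new step can be read from compound 2 to compound 4, because both stand at the same limit: the limit of > 15 uM in this assay, at which 3 of the 4 values shown sit.

From the compounds shown here alone, whether 4-methylpiperazin-1-yl in place of 4-methyl-1,4-diazepan-1-yl shifts this assay on the core of compound 2 as it does on the core of compound 3 stays open.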